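Aryl swap on the triazole in a weak antiproliferative series

This account rests on a few compounds, and the source may have more. Where it says the series, first, only, none or still open, it means among the compounds named here.

Working notes. The shared core is seen in compound 1 `N#CC1=C(N)Oc2c(c3nc4ccccc4nc3c3ccccc23)C12C(=O)N(Cc1cnnn1-c1ccccc1Br)c1ccccc12` and compound 2 `N#CC1=C(N)Oc2c(N)cc3nc4ccccc4nc3c2C12C(=O)N(Cc1cnnn1-c1ccccc1Br)c1ccccc12`. In a functional assay on MCF7 cells (Homo sapiens) for antiproliferative activity, read by MTT assay, with a stated time of 48 h (a higher number here means a weaker inhibitor, a lower number a stronger inhibitor), compound 1 reaches only a limit, > 50000 nM, sitting at the limit of > 50000 nM in this assay, at which 1 of the 2 values shown sits. In this assay, among the measured compounds shown here, compound 2 gives 30700 nM, the only number in hand, so compound 2 stands alone among the values rather than within any ordering. Compound 3 `N#CC1=C(N)Oc2c(N)cc3nc4ccccc4nc3c2C12C(=O)N(Cc1cnnn1-c1ccc(Cl)cc1[N+](=O)[O-])c1ccccc12` differs from compound 2 by 4-chloro-2-nitrophenyl in place of 2-bromophenyl on an aromatic nitrogen. For the measured compounds named here, no measured pair covers this change, so in this assay no step beyond the usual scatter is expected in either direction. Compound 3 is expected near 30000 nM, in the range 10000 nM to 80000 nM. This amounts to an expected step of a 1.0-fold lower number from compound 2 to compound 3 (0.01 log units; within the scatter).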

Compound 3, half-maximal inhibitory concentration: > 50000 nM
Compound 3 was reported as a limit (the forecaster's own chance of this, stated with the estimate: 25%); middle value at least 1.6-fold (0.22 log units) away from the limit.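

In this assay compound 3 is reported only as a limit, > 50000 nM. Putting 4-chloro-2-nitrophenyl in place of 2-bromophenyl on the aromatic nitrogen gives an at least 1.6-fold higher number from compound 2 to compound 3 (0.21 log units; that floor lies within the scatter), so this position has not yet yielded a number stronger than that of the 2-bromophenyl compound, and the true size of the step cannot be read. The series shown now sits mostly at the limit: the limit of > 50000 nM in this assay, at which 2 of the 3 values shown sit.

Still open, from the compounds shown here alone, is how a plain phenyl, a 4-chlorophenyl, a 2-nitrophenyl or an aminophenyl on this nitrogen would read in this assay. The compounds shown do not separate the chlorine from the nitro group.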